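This account rests on a few compounds, and the source may have more. Where it says the series, first, only, none or still open, it means among the compounds named here.

In a functional assay on A549 cells (Homo sapiens) for antiproliferative activity, read by MTT assay, with a stated time of 72 h (on this read-out lower numbers stand for stronger inhibition and higher numbers for weaker inhibition), compound 1 (`Cc1noc(C)c1-c1nn(Cc2ccc(C(=O)NC3CC(C)(C)N([O])C(C)(C)C3)cc2)c(=O)c2ccccc12`) gives 84300 nM, the highest of the three numbers at hand. Compound 2 (`Cn1cc(-c2nn(Cc3ccc(C(=O)NC4CC4)cc3)c(=O)c3ccccc23)cn1`) gives 51200 nM, which lies within the scatter of that value. Compound 3 (`Cn1cc(-c2nn(Cc3ccc(C(=O)NC4CC(C)(C)N([O])C(C)(C)C4)cc3)c(=O)c3ccccc23)cn1`) gives 37300 nM and alone stands clear of it, the gap being a 2.3-fold lower number from compound 1 to compound 3 (0.35 log units; beyond the scatter). That gap comes with 1-methyl-1H-pyrazol-4-yl in place of 3,5-dimethyl-1,2-oxazol-4-yl on an aromatic carbon, a place left unchanged on the way to compound 4 (`Cc1noc(C)c1-c1nn(Cc2ccc(C(=O)NC3CCCCC3)cc2)c(=O)c2ccccc12`), so it says little here. The change to compound 4 falls instead on an amide-type nitrogen, where cyclohexyl replaces the group of 11 heavy atoms: a group of 6 heavy atoms (6 carbon; one six-membered non-aromatic ring of carbon only) in place of a group of 11 heavy atoms (9 carbon, 1 nitrogen, 1 oxygen; one six-membered non-aromatic ring with 1 hetero atom), on an amide-type nitrogen. For the measured compounds named here, the nearest evidence is the one measured step on that nitrogen, where the same group of 11 heavy atoms replaced a group of 3 heavy atoms with the other aromatic substituent in place. No step beyond the scatter is therefore expected in this assay because a 1.4-fold lower number from compound 2 to compound 3 (0.14 log units; within the scatter) is all that this nitrogen has shown so far. That evidence is indirect, since cyclohexyl itself has not been measured. The step estimated here is a 1.1-fold higher number from compound 1 to compound 4 (0.03 log units; within the scatter), with no firm direction expected. For compound 4 the expected value is 90000 nM, with an estimated range from 40000 nM to 200000 nM.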

Compound 4, half-maximal inhibitory concentration: > 100000 nM
Compound 4: only a limit was reported; the forecaster's own chance of this, stated with the estimate: 20%; middle value at least 1.1-fold (0.04 log units) from the limit.
By their numbers in this assay, from the lowest: compounds 3, 2 and 1 (each within the scatter of the next, the first and the last beyond it). At a limit, above all of these: compound 4.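

In this assay compound 4 gives > 100000 nM, which is a limit of the assay and not a number. For the compounds shown here, on the amide-type nitrogen, the change from the group of 11 heavy atoms to cyclohexyl, with the rest of compound 1 left as it is, gives an at least 1.1-fold higher number from compound 1 to compound 4 (0.07 log units; that floor lies within the scatter); this is only a floor, so the true size of the step stays unknown, and the reading adds a second change at this nitrogen to the one earlier step there, a 1.4-fold lower number from compound 2 to compound 3 (0.14 log units; within the scatter). It is also the first reading at this nitrogen with a ring of carbon only, which has no hydrogen-bond acceptor, and the result can be placed no more exactly than this: the limit of > 100000 nM in this assay, at which 1 of the 4 values shown sits.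

The compounds shown leave open how a piperidin-4-yl or a 4-hydroxycyclohexyl group would read on this nitrogen, either of which would sit between cyclohexyl and the group of 11 heavy atoms in its atoms. They also leave open which part of the group of 11 heavy atoms, its ring nitrogen with its oxygen or its four methyl groups, goes with the value of compound 1, since the change to cyclohexyl removes these parts together.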